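Swapping Methoxy for Trifluoromethylsulfanyl on the Aromatic Carbon

The source may report more compounds than this note shows. Statements on the series, on what has been measured and on what is new or still open speak of the compounds shown alone.

Among the measured compounds shown here, compound 2 `COc1ccc(CNC(=O)c2ccc(C(C)(C)C)cc2)cc1` gives 150 nM in an assay on HeLa cells with Bile acid receptor (Homo sapiens) as the target, read by a luciferase reporter, with a stated time of 24 h (a lower number here means that less compound is needed, a higher number that more compound is needed for the effect), the lowest of the two numbers so far; compound 1 `CC(=O)Nc1ccc(CNC(=O)c2ccc(C(C)(C)C)cc2)cc1` gives 2900 nM in this assay. For the measured compounds named here, the single measured step, a 19-fold lower number from compound 1 to compound 2 (1.29 log units; beyond the scatter), also changed the group on that aromatic carbon. Compound 3 `CC(C)(C)c1ccc(C(=O)NCc2ccc(SC(F)(F)F)cc2)cc1` carries (trifluoromethyl)sulfanyl in place of methoxy on an aromatic carbon. That earlier step shows the aromatic carbon tolerates large swings, but it involved other groups, so it bears on this change only loosely. The expected step is a 1.5-fold lower number from compound 2 to compound 3 (0.18 log units; within the scatter). Compound 3 is therefore estimated at 100 nM, between 25 nM and 400 nM.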

Compound 3, half-maximal effective concentration: 0.4 nM
Compound 3: the middle estimate sits 250-fold (2.40 log units) above what was measured, and the stated range ends above it.
By their numbers in this assay, from the lowest: compound 3; then compound 2; then compound 1.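

Methoxy did not mark the limit at this position on the aromatic carbon: (trifluoromethyl)sulfanyl in its place gives a 380-fold lower number from compound 2 to compound 3 (2.57 log units; beyond the scatter), and in place of acetamido it gives a 7300-fold lower number from compound 1 to compound 3 (3.86 log units; beyond the scatter). Compound 3 therefore has the lowest number of the three in this assay, and the position responds far more strongly than the first two compounds showed. Nothing measured here explains the size of these steps. The compounds shown leave open whether the sulfur atom is needed, since neither a trifluoromethyl nor a trifluoromethoxy group appears at this position. They also leave open whether a simple methylsulfanyl group, without fluorine, would give a similar number.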